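Acetyl for Cyano on a Fluorinated Diaryl Urea

A few compounds are considered here, and "the series" means these few. Any claim that something is new, unique, unknown or untested is made for them only; others in the source may bear on it.

Compound 1 `N#Cc1ccc(NC(=O)Nc2ccc(F)c(C(F)(F)F)c2)cc1`, in a physicochemical assay for lipophilicity, read by HPLC, measured as octanol-water partition, at pH 7.2; a lower number here means a more polar compound, a higher number a more lipophilic compound: 3.8
Compound 2 `O=C(Nc1ccnc(C(F)(F)F)c1)Nc1ccc(F)c(C(F)(F)F)c1`, in this assay: 3.8
Compound 3 `Cc1cc(NC(=O)Nc2ccc(F)c(C(F)(F)F)c2)on1`, in this assay: 3.2

Three ureas share the same fluorinated, trifluoromethyl-bearing aryl half and differ in the other half. In this assay compound 1 and compound 2 stand level at the digits shown, and together they are the highest of the three numbers; their values lie within the scatter of each other, so no order between them can be read. Compound 3 sits clearly lower than compound 1, a gap that is beyond the scatter.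

Compound 4 `CC(=O)c1ccc(NC(=O)Nc2ccc(F)c(C(F)(F)F)c2)cc1` is the next step from compound 1. The difference is acetyl in place of cyano on an aromatic carbon. For the measured compounds named here, no measured pair shows this exact exchange, so the size of the step is not known from the data. Both groups are small and uncharged and each brings a single hydrogen-bond acceptor, so the step in this assay is expected to be small, in either direction or none beyond the scatter. On that basis compound 4 is expected to give 3.8, between 3.4 and 4.2, with the expected step being no change at the digits printed from compound 1 to compound 4 (within the scatter).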

Compound 4, distribution coefficient: 3.6
Estimate against measurement, compound 4: 0.20 log units above, and the stated range covers the measured number.
By their numbers in this assay, from the lowest: compound 3; then compounds 4, 1 and 2 (each within the scatter of the next).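

In this assay, acetyl in place of cyano on this aromatic carbon, para to a large group, gives a number 0.20 log units lower from compound 1 to compound 4 (within the scatter) and so provides the only direct reading of a change at this position among the compounds shown. The earlier compounds shown here differ in the whole of the other aryl half, whereas this pair isolates one group and shows that 3 heavy atoms in acetyl can replace 2 in cyano without a step beyond the scatter. Nothing measured here gives a cause for this step.

From the compounds shown here alone, whether an amine or a carboxylic acid on the same aromatic carbon would give a step beyond the scatter remains open, as does the outcome for a longer acyl chain. Going by these compounds, it is also open whether acetyl in place of cyano would read the same on a different core.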